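Swapping a Five-Membered Ring for a Six-Membered One

A few compounds are considered here, and "the series" means these few. Any claim that something is new, unique, unknown or untested is made for them only; others in the source may bear on it.

Of the compounds shown here, three sharing one fused core have been measured in a functional assay on CHO-K1 cells for antagonist activity at adenosine receptor A1 (Homo sapiens), read by a beta-galactosidase reporter and cAMP accumulation, with stated times of 15 min and 6 h; a higher number here means a weaker inhibitor, a lower number a stronger inhibitor. Compound 1 `Cc1ccc(-c2nc(N)c3cc(-c4ccccc4)sc3n2)o1` gives 520 nM. Compound 2 `Nc1nc(-c2ncco2)nc2sc(Cc3ccccc3)cc12` gives 310 nM, and compound 3 `Nc1nc(-c2ccccc2)nc2sc(-c3ccccc3)cc12` gives 237 nM. On these three numbers compound 2 stands second highest; its gap to compound 3 and its gap to compound 1 both lie within the usual scatter of such measurements, so none of the three can be called stronger or weaker than another with confidence.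

The step now followed leads from compound 2 to compound 4 `Nc1nc(-c2cccnc2)nc2sc(Cc3ccccc3)cc12`, which has not yet been measured in this assay. The change is pyridin-3-yl in place of 1,3-oxazol-2-yl on an aromatic carbon: a five-membered aromatic ring with two hetero atoms gives way to a six-membered aromatic ring with one hetero atom.

Going by the values given here, the one measured step that bears on this, a 2.2-fold lower number from compound 1 to compound 3 (0.34 log units; beyond the scatter), also exchanges a five-membered ring for a six-membered ring on the same aromatic carbon, and it brought a modest lowering of the number. A similar, slightly smaller move is therefore expected here, a 1.6-fold lower number from compound 2 to compound 4 (0.19 log units; within the scatter). For compound 4 the expected value in this assay is 200 nM, within a range from 80 nM to 500 nM.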

Compound 4, inhibition constant: 1420 nM
Beside the measured number, compound 4's estimate is 7.1-fold (0.85 log units) below it; measured number above the stated range.
By their numbers in this assay, from the lowest: compounds 3, 2 and 1 (each within the scatter of the next, the first and the last beyond it); then compound 4.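

Putting pyridin-3-yl in place of 1,3-oxazol-2-yl brings a 4.6-fold higher number from compound 2 to compound 4 (0.66 log units; beyond the scatter) in this assay, which shows that this carbon of the core, between two ring nitrogen atoms, does not accept every aromatic ring equally. The earlier step, a 2.2-fold lower number from compound 1 to compound 3 (0.34 log units; beyond the scatter), also put a six-membered aromatic ring in place of a five-membered one on this carbon, yet it ran the opposite way, so across these two pairs ring size alone does not set the direction of the change. The two steps also differ in other ways: the pyridin-3-yl ring holds a ring nitrogen while phenyl holds none, and elsewhere on the core the first pair carries phenyl and the second benzyl.

Nothing available explains why the two steps part ways. Also open, as far as these compounds go, is how pyridin-4-yl or 1,3-thiazol-2-yl would fare at this carbon with the benzyl group kept in place, and whether either would follow compound 2 or compound 4.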